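Swapping a benzyl end for a vinyl end

The source may report more compounds than this note shows. Statements on the series, on what has been measured and on what is new or still open speak of the compounds shown alone.

Compound 1 `O=C(CCCCCc1ccccc1)c1nc2ncccc2s1`, compound 2 `O=C(CCCCCCc1ccccc1)c1ncc(C(=O)C(F)(F)F)o1` and compound 3 `O=C(CCCCCCCCc1ccccc1)c1nc2ncccc2o1` were tested in an assay on HEK-293T cells for inhibition of diacylglycerol lipase-alpha (Homo sapiens), read by colorimetric assay; on this read-out higher numbers stand for weaker inhibition and lower numbers for stronger inhibition. For compound 1 the assay reports only a limit, > 10000 nM. In this assay compound 2 gives 1820 nM. In this assay compound 3 gives 3.63 nM, the lowest of the two numbers, far from compound 2 and well beyond the usual scatter. Compound 4 `C=CCCCCCCCC(=O)c1nc2ncccc2o1` has not been measured; it differs from compound 3 by vinyl in place of benzyl on a saturated chain carbon, seven bonds along the chain from a carbonyl carbon. Among the compounds with values here, no step between measured compounds is known, so the size of this change can only be expected, not read off. The expected change, toward weaker inhibition, is a 14-fold higher number from compound 3 to compound 4 (1.14 log units; beyond the scatter). For compound 4 the estimate is 50 nM, within a range from 8 nM to 400 nM.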

Compound 4, half-maximal inhibitory concentration: 550 nM
The estimate for compound 4 lay 11-fold (1.04 log units) below the measured number, outside the stated range (above it).
By their numbers in this assay, from the lowest: compound 3; then compound 4; then compound 2. At a limit, above all of these: compound 1.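

In this assay the end of the chain proves to matter greatly: vinyl in place of benzyl on a saturated chain carbon, seven bonds along the chain from a carbonyl carbon, gives a 150-fold higher number from compound 3 to compound 4 (2.18 log units; beyond the scatter) even though the rest of the structure stays the same. Within the data shown here, this pair is the first to show the effect of one change alone, since the earlier compounds differ in more than one place. Nothing shown explains the size of this step.

Going by these compounds, a plain ethyl group, an amine or a carboxylic acid at this chain end remains open. So does whether benzyl keeps its lead on a longer chain.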